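The source may hold more compounds than are shown below. What is called first, only, known or untested is meant among the compounds shown, and "the series" means these compounds.

Measured so far:
compound 1 `COc1ccc(/C=C/C[C@H]2C[C@H]([C@H](O)c3ccc(OC)c(OC)c3)CO[C@@H]2c2ccc(OC)c(OC)c2)cc1OC` — 34600 nM
compound 2 `COc1ccc(/C=C/C[C@@H]2C[C@@H]([C@@H](OC(C)=O)c3ccc(OC)c(OC)c3)CO[C@H]2c2ccc(OC)c(OC)c2)cc1OC` — limit
compound 3 `COc1cccc(/C=C/C[C@@H]2C[C@@H]([C@@H](O)c3ccc(OC)c(OC)c3)CO[C@H]2c2ccc(OC)c(OC)c2)c1` — 16400 nM

In a functional assay on HeLa cells (Homo sapiens) for cytotoxicity, read by WST assay, with a stated time of 48 h (on this read-out lower numbers stand for stronger inhibition and higher numbers for weaker inhibition), compound 3 gives 16400 nM, the lowest of the two numbers shown. Compound 1 sits higher, with 34600 nM in this assay, a gap beyond the scatter. Compound 2 gives only a limit, > 100000 nM, in this assay; this is the limit of > 100000 nM in this assay, at which 1 of the 3 values shown sits, not a number. Within the data shown here, no pair among the measured compounds differs in one place, so no measured step can be read off.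

Compound 4 `COc1ccc(/C=C/C[C@@H]2C[C@@H]([C@@H](O)c3ccc(OC)c(OC)c3)CO[C@H]2c2ccc(OC)c(OC)c2)cc1OC` is not yet measured. It differs from compound 3 by methoxy in place of hydrogen on an aromatic carbon, so that the 3-methoxyphenyl on the ethenyl chain becomes 3,4-dimethoxyphenyl. With no measured step of this kind in the set, the expectation rests on the spread of the two numbers shown. A modest step upward from compound 3 is expected, a 1.8-fold higher number from compound 3 to compound 4 (0.26 log units; within the scatter), and compound 4 is estimated at 30000 nM in this assay, between 12000 nM and 80000 nM.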

Compound 4, half-maximal inhibitory concentration: 30600 nM
For compound 4 the middle estimate is 1.0-fold (0.01 log units) below the measured one, within the range that was stated.
By their numbers in this assay, from the lowest: compounds 3, 4 and 1 (each within the scatter of the next, the first and the last beyond it). At a limit, above all of these: compound 2.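

In this assay, methoxy in place of hydrogen on an aromatic carbon, taking 3-methoxyphenyl to 3,4-dimethoxyphenyl, gives a 1.9-fold higher number from compound 3 to compound 4 (0.27 log units; within the scatter), so this added group on the ethenyl side chain has no effect that can be told from the scatter. Hydrogen in place of acetyl on the oxygen gives an at least 3.2-fold lower number from compound 2 to compound 4 (0.51 log units; beyond the scatter), the only new step beyond the scatter, and it rests on a limit rather than a number: the limit of > 100000 nM in this assay, at which 1 of the 4 values shown sits. The change in configuration at 4 of 5 stereo elements gives a 1.1-fold lower number from compound 1 to compound 4 (0.05 log units; within the scatter), so the drawn configuration does not separate this pair: the fact that compounds 1 and 4 differ only in the configuration as drawn.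

As far as these compounds go, whether an amine or a carboxylic acid on that same aromatic carbon would move the number stays open. So does whether a methyl ether in place of the free hydroxyl would match acetyl or hydrogen.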